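Rearranging the methylpyrazole of compound 3

A few compounds are considered here, and "the series" means these few. Any claim that something is new, unique, unknown or untested is made for them only; others in the source may bear on it.

In a functional assay on VCaP cells (Homo sapiens) for antiproliferative activity, read by CCK-8 assay, with a stated time of 6 days (a lower number here means a stronger inhibitor, a higher number a weaker inhibitor), compound 1 (`CCN(c1ccc(C#N)c(Cl)c1)c1cc(-n2cnc3ccccc32)ccc1C`), with a 1H-benzimidazol-1-yl group, gives 8560 nM as its result. Compound 2 (`CCN(c1ccc(C#N)c(Cl)c1)c1cc(-c2ccccc2)ccc1C`), with phenyl in that place, shows only a limit of the assay (> 30000 nM). Compound 3 (`CCN(c1ccc(C#N)c(Cl)c1)c1cc(-c2ccnn2C)ccc1C`), with 1-methyl-1H-pyrazol-5-yl, stands lowest at 1670 nM and is the strongest of the three. Exchanging this one group has clearly mattered: the steps are an at least 3.5-fold higher number from compound 1 to compound 2 (0.54 log units; beyond the scatter) and an at least 17-fold lower number from compound 2 to compound 3 (1.25 log units; beyond the scatter), both resting on that limit.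

Compound 4 (`CCN(c1ccc(C#N)c(Cl)c1)c1cc(-c2c[nH]nc2C)ccc1C`) has the same atoms as compound 3 joined differently, with 3-methyl-1H-pyrazol-4-yl in place of 1-methyl-1H-pyrazol-5-yl on an aromatic carbon. Among the compounds with values here, no measured step links two pyrazoles, so the steps so far, which all exchange one ring type for another, give only a rough upper guide. Since both groups are one five-membered aromatic ring with 2 hetero atoms, a change smaller than a 5.1-fold lower number from compound 1 to compound 3 (0.71 log units; beyond the scatter) is expected in this assay and no firm direction can be foreseen. The expected step is a 1.1-fold lower number from compound 3 to compound 4 (0.05 log units; within the scatter) and it is estimated to lie within the scatter. For compound 4 the estimated value is 1500 nM with an expected range (350 nM to 7000 nM).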

Compound 4, half-maximal inhibitory concentration: 3190 nM
Compound 4: the middle estimate sits 2.1-fold (0.33 log units) below what was measured; measured number inside the range.
By their numbers in this assay, from the lowest: compounds 3 and 4 (each within the scatter of the next); then compound 1. At a limit, above all of these: compound 2.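

In this assay, the step between the two methylpyrazoles is a 1.9-fold higher number from compound 3 to compound 4 (0.28 log units; within the scatter) and stays within the scatter, even though the ring is attached through a different atom and goes from 0 hydrogen-bond donors and 2 hydrogen-bond acceptors to 1 hydrogen-bond donor and 1 hydrogen-bond acceptor. Compound 4 also keeps a clear margin over the benzimidazole with a 2.7-fold lower number from compound 1 to compound 4 (0.43 log units; beyond the scatter), so at this place, para to a methyl group, the advantage of a methylpyrazole over the 1H-benzimidazol-1-yl group is not tied to one arrangement of that ring. Compound 2 gives only a limit of the assay, so its step is a bound and not a measured size, an at least 9.4-fold lower number from compound 2 to compound 4 (0.97 log units; beyond the scatter): the limit of > 30000 nM in this assay, at which 1 of the 4 values shown sits.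

With only these two arrangements, the effects of moving the methyl group, moving the point of attachment and adding the ring hydrogen on nitrogen cannot be told apart. As far as these compounds go, it remains open how a 1-methyl-1H-pyrazol-4-yl group, a pyrazole with no methyl group, or a ring carrying an amine or a carboxylic acid would behave at this place.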